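The compounds below may be only part of what the source reports. "The series", "measured", "known", "first", "only" and "open" are said of these compounds alone.

Measured so far:
- compound 1 `CC(C)NCCS(=O)(=O)NC(=O)c1ccc(Nc2nc(NC3(c4ccc(Cl)cc4)CC3)nc(OCC(F)(F)F)n2)cc1` gives 100%
- compound 2 `CC(C)OC(=O)NCCS(=O)(=O)NC(=O)c1ccc(Nc2nc(NC3(c4ccc(Cl)cc4)CC3)nc(OCC(F)(F)F)n2)cc1` gives 73%
- compound 3 `O=C(NS(=O)(=O)c1ccccc1)c1ccc(Nc2nc(NC3(c4ccc(Cl)cc4)CC3)nc(OCC(F)(F)F)n2)cc1` gives 100%

In an ADME assay on microsomes from liver (Rattus norvegicus) for metabolic stability, with a stated time of 10 min (a lower number here means that less of the compound is left, a higher number that more of the compound is left), compound 3 shares the top of this small set with compound 1, since no change at the digits printed from compound 1 to compound 3 (within the scatter), and it sits clearly higher than compound 2, since a number 27 percentage points higher from compound 2 to compound 3 (beyond the scatter). Compound 4 `O=C(NS(=O)(=O)C1CC1)c1ccc(Nc2nc(NC3(c4ccc(Cl)cc4)CC3)nc(OCC(F)(F)F)n2)cc1` is the next step: cyclopropyl in place of phenyl on a sulfonyl sulfur. Within the data shown here, no measured step swaps one ring for another at that sulfonyl sulfur; the two steps that touch this position, no change at the digits printed from compound 1 to compound 3 (within the scatter) and a number 27 percentage points higher from compound 2 to compound 3 (beyond the scatter), show that groups here can leave the readout unchanged or move it modestly. With compound 3 already at the highest number shown, compound 4 is expected to stay close, with a number 7 percentage points lower from compound 3 to compound 4 (within the scatter) as the estimated step and 93% as the estimate, within 75% to 100%.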

Compound 4, percent of the compound remaining: 85%
Beside the measured number, compound 4's estimate is 8 percentage points above it, within the range that was stated.
By their numbers in this assay, from the lowest: compound 2; then compound 4; then compounds 1 and 3 (each within the scatter of the next).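

At this sulfonyl sulfur, one ring can't simply be traded for another without consequence in this assay: cyclopropyl in place of phenyl gives a number 15 percentage points lower from compound 3 to compound 4 (beyond the scatter). The cyclopropyl group falls between the two open-chain groups, with a number 12 percentage points higher from compound 2 to compound 4 (beyond the scatter) against the 2-((isopropoxycarbonyl)amino)ethyl chain and a number 15 percentage points lower from compound 1 to compound 4 (beyond the scatter) against the 2-(isopropylamino)ethyl chain. No available evidence accounts for these differences. The compounds shown cannot separate ring size from the loss of the aromatic ring. Going by these compounds, whether a cyclohexyl ring or a simple methyl group would stay nearer the phenyl or the cyclopropyl result remains open.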